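Two Ring Stereocentres Reversed: From Compound 2 to Compound 3

A few compounds are considered here, and "the series" means these few. Any claim that something is new, unique, unknown or untested is made for them only; others in the source may bear on it.

Measured so far:
compound 1, `CCCCSc1nsnc1[C@@H]1CN2CCC[C@@H]1C2`, gives > 3 mg/kg in a functional assay on the whole organism for inhibition, with Rattus norvegicus as the target; a higher number here means that more compound is needed for the effect, a lower number that less compound is needed
compound 2, `CCCSc1nsnc1[C@H]1CN2CCC[C@H]1C2`, gives > 3 mg/kg in this assay

Compound 2 stands at a limit of this assay rather than at a measured number. Going by the values given here, compound 1 also sits at a limit in this assay, so neither reading gives a firm point to compare; the only evidence is the limit of > 3 mg/kg in this assay, at which 2 of the 2 values shown sit.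

Compound 3, `CCCSc1nsnc1[C@@H]1CN2CCC[C@@H]1C2`, differs from compound 2 in its drawn configuration only: the two compounds have the same atoms and bonds; at least one stereo element is drawn with a configuration in one of them and without one in the other: 2 of 3 stereo elements differ; a stereocentre at a saturated ring carbon is drawn R in compound 2 and S in compound 3; a stereocentre at a saturated ring carbon is drawn R in compound 2 and S in compound 3. Compound 1 is drawn with the same ring configuration as compound 3. Among the compounds with values here, no step between measured compounds differing in one place is available, so no size for a configuration change can be read from the data. Given that both measured values are limits, no step beyond the usual scatter is expected in either direction. Compound 3 is expected to give 5 mg/kg in this assay, estimated between 1 mg/kg and 30 mg/kg. The expected step that the limit leaves unreadable from compound 2 to compound 3 is an estimate only.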

Compound 3, dose for half-maximal effect: > 3 mg/kg
Compound 3: a limit, no number; the forecaster's own chance of this, stated with the estimate: 70%; the middle value lies beyond the limit too.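

Compound 3 gives > 3 mg/kg in this assay, which is a limit and not a number. Compound 1 and compound 2 also sit at a limit, so no step to compound 3 can be read: the limit of > 3 mg/kg in this assay, at which 3 of the 3 values shown sit.

The compounds shown leave open how much of each is needed for the effect, and whether the ring configuration or the chain changes that amount.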